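Replacing 4-(methylsulfanyl)phenyl with thiophen-3-yl

The compounds below may be only part of what the source reports. "The series", "measured", "known", "first", "only" and "open" are said of these compounds alone.

In a functional assay on DU-145 cells (Homo sapiens) for inhibition, read by MTT assay, with a stated time of 48 h (on this read-out higher numbers stand for weaker inhibition and lower numbers for stronger inhibition), compound 1 `CS(=O)(=O)c1ccc(-c2nc3ccccn3c2Sc2ccccc2)cc1` gives 67800 nM, compound 2 `CSc1ccc(-c2nc3ccccn3c2Sc2ccccc2)cc1` gives 52100 nM and compound 3 `Clc1ccc2nc(-c3ccccc3)c(Sc3ccccc3)n2c1` gives 56300 nM. These three values lie within the usual scatter of one another, so compound 2 stands level with the other two and none of them can be ranked.

The unmeasured compound 4 `c1ccc(Sc2c(-c3ccsc3)nc3ccccn23)cc1` differs from compound 2 in one place: thiophen-3-yl in place of 4-(methylsulfanyl)phenyl on an aromatic carbon. In words, thiophen-3-yl takes the place of 4-(methylsulfanyl)phenyl on an aromatic carbon, next to the ring atom that bears a phenylsulfanyl group.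

Among the measured compounds shown here, only one measured step bears on this change: a 1.3-fold lower number from compound 1 to compound 2 (0.11 log units; within the scatter). It puts methylsulfanyl in place of methylsulfonyl on an aromatic carbon, and it stays within the scatter. For the measured compounds named here, that step alters only a small group, whereas compound 4 replaces the whole 4-(methylsulfanyl)phenyl group, so the guidance is thin and no measured step shows such an exchange.

With nothing pointing either way, the expected result in this assay is a 1.1-fold higher number from compound 2 to compound 4 (0.02 log units; within the scatter), which means no expected change beyond the scatter. For compound 4 the estimated value is 55000 nM, with an expected range from 22000 nM to 120000 nM.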

Compound 4, half-maximal inhibitory concentration: 85900 nM
The estimate for compound 4 lay 1.6-fold (0.19 log units) below the measured number; the range from low to high includes it.
By their numbers in this assay, from the lowest: compounds 2, 3, 1 and 4 (each within the scatter of the next).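

In this assay, the change gives a 1.6-fold higher number from compound 2 to compound 4 (0.22 log units; within the scatter), which lies within the scatter, so compound 4 cannot be ranked against compound 2. The earlier step altered only a small group on the aromatic ring attached at this carbon, whereas this one replaces the whole 4-(methylsulfanyl)phenyl group with thiophen-3-yl. This shows that a six-membered aromatic ring of carbon only, with 8 heavy atoms, can give way to a five-membered aromatic ring with 1 hetero atom and 5 heavy atoms, on this aromatic carbon next to the ring atom that bears a phenylsulfanyl group, without a change beyond the scatter, though no measurement is available that would explain this result.

Every number shown here is close to the next, so it remains open whether any group on this carbon can move the read-out beyond the scatter at all. An amine or a carboxylic acid on the ring at this carbon, or a longer chain in place of that ring, would test this, and the compounds shown cannot say in which direction such a group would move the number.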